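Tail flick series: one ester-to-acid pair still open

A few compounds are considered here, and "the series" means these few. Any claim that something is new, unique, unknown or untested is made for them only; others in the source may bear on it.

Measured so far:
compound 1 `CC(C)[C@H](NC(=O)CN(c1nc(Cl)nc2[nH]cnc12)C1CC1)C(=O)OCc1ccccc1`: 17.9%
compound 2 `NCCCC[C@H](NC(=O)CN(c1nc(Cl)nc2[nH]cnc12)C1CC1)C(=O)OCc1ccccc1`: 9.88%
compound 3 `NCCCC[C@H](NC(=O)CN(c1nc(Cl)nc2[nH]cnc12)C1CC1)C(=O)O`: 11.6%

The read-out is a functional assay on the whole organism (Tail, strain ICR) with Mus musculus as the target, in the tail flick test, with a stated time of 150 min, at a dose of 25 umol/kg by the oral route; on this read-out lower numbers stand for a weaker effect and higher numbers for a stronger effect at the one dose given. Compound 1 and compound 2 share a core and differ by isopropyl in place of 4-aminobutyl on a saturated chain carbon bound to an amide-type nitrogen and a carbonyl carbon; this gives a number 8 percentage points higher from compound 2 to compound 1 (within the scatter). Compound 2 and compound 3 differ by hydrogen in place of benzyl on an oxygen next to a carbonyl group, giving a number 1.7 percentage points higher from compound 2 to compound 3 (within the scatter). Compound 4 `CC(C)[C@H](NC(=O)CN(c1nc(Cl)nc2[nH]cnc12)C1CC1)C(=O)O` is not yet measured. It differs from compound 3 by isopropyl in place of 4-aminobutyl on a saturated chain carbon bound to an amide-type nitrogen and a carbonyl carbon, the same change that separates compound 2 from compound 1, occurring twice among these compounds; the cores of the two pairs differ by hydrogen in place of benzyl on an oxygen next to a carbonyl group, and the place of the change is described identically in both pairs, so it is taken as the same change.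

For compound 4 a step of a number 8.4 percentage points higher from compound 3 to compound 4 (within the scatter) is expected, resting on a number 8 percentage points higher from compound 2 to compound 1 (within the scatter) carried over to the acid pair. For the measured compounds named here, compound 4 is thus estimated at 20% in this assay, with a range from 8% to 32%, and this expectation leans on only one earlier step that itself lay within the scatter.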

Compound 4, a percentage reported as activity, at one dose (the size of the read-out at that dose, not a potency): 7.86%
Compound 4: middle estimate off by 12.1 percentage points, on the high side; measured number below the stated range.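

In this assay, isopropyl in place of 4-aminobutyl on the acid core gives a number 3.7 percentage points lower from compound 3 to compound 4 (within the scatter), and this does not separate from the same change on the benzyl ester core: the same change on two cores in this assay, a number 8 percentage points higher (within the scatter) from compound 2 to compound 1 and a number 3.7 percentage points lower (within the scatter) from compound 3 to compound 4, 11.8 percentage points apart, within the scatter of two such steps

Hydrogen in place of benzyl on the isopropyl core gives a number 10 percentage points lower from compound 1 to compound 4 (within the scatter), and this likewise does not separate from the same change on the 4-aminobutyl core: the same change on two cores in this assay, a number 1.7 percentage points higher (within the scatter) from compound 2 to compound 3 and a number 10 percentage points lower (within the scatter) from compound 1 to compound 4, 11.8 percentage points apart, within the scatter of two such steps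

Neither change therefore shows a dependence on the core, but with every step inside the scatter, these pairs also do not show that either change carries over reliably from one core to the other.

The compounds shown leave open whether a methyl ester in place of the benzyl ester, or a phenyl group in place of isopropyl, would give a step beyond the scatter.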